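Swapping a Sulfur Hydrogen for a 3-Chlorobenzyl Group

The source may report more compounds than this note shows. Statements on the series, on what has been measured and on what is new or still open speak of the compounds shown alone.

Measured so far in a functional assay on BGC-823 cells (Homo sapiens) for antiproliferative activity, read by MTT assay, with a stated time of 24 h; a higher number here means a weaker inhibitor, a lower number a stronger inhibitor:
Compound 1 `Sc1nnc(-c2ccc3c(c2)OCCO3)n1-c1ccccc1` gives 47000 nM
Compound 2 `O=[N+]([O-])c1ccccc1CSc1nnc(-c2ccc3c(c2)OCCO3)n1-c1ccccc1` gives 26500 nM
Compound 3 `O=[N+]([O-])c1cccc(CSc2nnc(-c3ccc4c(c3)OCCO4)n2-c2ccccc2)c1` gives 30100 nM

Compound 1 carries a bare sulfur and has the highest number of the three; the other two lie within the scatter of it, so no order among them can be claimed. The step of a 1.8-fold lower number from compound 1 to compound 2 (0.25 log units; within the scatter) and the step of a 1.6-fold lower number from compound 1 to compound 3 (0.19 log units; within the scatter) both come from putting a nitrobenzyl group on that sulfur, and neither moved the number beyond the scatter. The step of a 1.1-fold higher number from compound 2 to compound 3 (0.06 log units; within the scatter) shows that shifting the nitro group around the ring also changed nothing that can be trusted.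

Compound 4 `Clc1cccc(CSc2nnc(-c3ccc4c(c3)OCCO4)n2-c2ccccc2)c1` is the next variation. Its change from compound 1 is 3-chlorobenzyl in place of hydrogen on a sulfur. The two nitrobenzyl steps are the ones that bear on it, since each adds a substituted benzyl group at the same sulfur, and each was small. A step of similar size, or none beyond the scatter, is therefore expected in this assay for compound 4, meaning a 1.6-fold lower number from compound 1 to compound 4 (0.19 log units; within the scatter). For compound 4 the expected value is 30000 nM, with a range from 13000 nM to 65000 nM.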

Compound 4, half-maximal inhibitory concentration: 51200 nM
Compound 4: middle estimate off by 1.7-fold (0.23 log units), on the low side; the measured number falls inside the stated range.
By their numbers in this assay, from the lowest: compounds 2, 3, 1 and 4 (each within the scatter of the next).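

With a 1.1-fold higher number from compound 1 to compound 4 (0.04 log units; within the scatter), a substituted benzyl group without a nitro group joins the two nitrobenzyl groups in leaving the number within the scatter of the bare sulfur in this assay. Chloro in place of nitro gives no readable change either, with a 1.7-fold higher number from compound 3 to compound 4 (0.23 log units; within the scatter) and with a 1.9-fold higher number from compound 2 to compound 4 (0.29 log units; within the scatter), so these four compounds show no effect of the benzyl group or of the group on its ring that rises above the scatter. No measurement at hand explains these numbers.

On these data alone, what remains open is whether any group on this sulfur can move the number beyond the scatter. A plain benzyl group, or a longer chain ending in an amine or a carboxylic acid, could answer that.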